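A few compounds are considered here, and "the series" means these few. Any claim that something is new, unique, unknown or untested is made for them only; others in the source may bear on it.

Measured so far in a functional assay on KM12 cells (Homo sapiens) for inhibition, read by sulforhodamine B assay, with a stated time of 48 h, tested at 10 uM; on this read-out lower numbers stand for less inhibition and higher numbers for more inhibition at the one concentration tested (going by the name of the read-out):
- compound 1 `c1ccc(-c2cn3ccnc3c(-c3ccc4ncn(C5CCCCC5)c4c3)n2)cc1`: 49%
- compound 2 `Clc1ccc(-c2cn3ccnc3c(-c3ccc4ncn(C5CCCCC5)c4c3)n2)cc1`: 10.6%

Compound 2 stands lowest of the two numbers; its nearest neighbour is compound 1, and the gap between them is a number 38.4 percentage points lower from compound 1 to compound 2 (beyond the scatter) when read from compound 1 to compound 2.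

Compound 3 `c1csc(-c2cn3ccnc3c(-c3ccc4ncn(C5CCCCC5)c4c3)n2)c1` is to be measured; it differs from compound 2 by thiophen-2-yl in place of 4-chlorophenyl on an aromatic carbon. For the measured compounds named here, the only step known is a number 38.4 percentage points lower from compound 1 to compound 2 (beyond the scatter), where chloro in place of hydrogen lowered the read-out sharply; here the chloro is lost together with its ring, so a step upward from compound 2 in this assay is expected, though the thiophen-2-yl has no precedent. Compound 3 is estimated at 35% (range 10% to 60%), an expected step of a number 24.4 percentage points higher from compound 2 to compound 3 (beyond the scatter).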

Compound 3, a percentage reported as inhibition, at one concentration (the size of the read-out at that concentration, not a potency): 4.89%
Compound 3: the middle estimate sits 30.1 percentage points above what was measured; measured number outside the range, below it.
By their numbers in this assay, from the lowest: compounds 3 and 2 (each within the scatter of the next); then compound 1.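

Thiophen-2-yl in place of phenyl at this position gives a number 44.1 percentage points lower from compound 1 to compound 3 (beyond the scatter) in this assay, so a low read-out here does not require the chloro of compound 2. Thiophen-2-yl in place of 4-chlorophenyl gives a number 5.7 percentage points lower from compound 2 to compound 3 (within the scatter), which leaves these two groups without an order, and of the three groups only the unsubstituted phenyl of compound 1 keeps a clearly higher number. No supporting data explain either step.

Open, as far as these compounds go, is how a pyridin-3-yl ring, or a phenyl carrying a methoxy or an amine, would read at this position. A single concentration also leaves the potency of all three compounds open.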